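Adding a hydroxy group to compound 1

The compounds below may be only part of what the source reports. "The series", "measured", "known", "first", "only" and "open" are said of these compounds alone.

In a functional assay on HOP-62 cells (Homo sapiens) for inhibition, read by sulforhodamine B assay (on this read-out higher numbers stand for weaker inhibition of growth and lower numbers for stronger inhibition of growth), compound 1 (`FC(F)(F)Oc1ccc(-c2ccc(-c3ccc(-c4nc5ccccc5[nH]4)cc3)cc2)cc1`) gives 100000 nM. Compound 2 (`COc1ccc(-c2ccc(-c3ccc(-c4nc5ccccc5[nH]4)cc3)cc2)cc1`) gives 100000 nM, and compound 3 (`CN(C)c1ccc(-c2ccc(-c3ccc(-c4nc5ccccc5[nH]4)cc3)cc2)cc1`) gives 100000 nM, so compound 1 stands level with both. Compound 4 (`Oc1cccc2[nH]c(-c3ccc(-c4ccc(-c5ccc(OC(F)(F)F)cc5)cc4)cc3)nc12`) carries hydroxy in place of hydrogen on an aromatic carbon of the core of compound 1: hydroxy in place of hydrogen on an aromatic carbon. The measured steps, no change at the digits printed from compound 1 to compound 2 (within the scatter), no change at the digits printed from compound 1 to compound 3 (within the scatter) and no change at the digits printed from compound 2 to compound 3 (within the scatter), all exchange a group elsewhere, and none touches this carbon. They therefore give only indirect guidance. A modest move towards stronger inhibition is expected, a 2.0-fold lower number from compound 1 to compound 4 (0.30 log units; within the scatter), though it may stay within the scatter. For compound 4 the estimated value is 50000 nM, with an expected range of 8000 nM to 100000 nM.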

Compound 4, concentration for 50% growth inhibition: 2270 nM
Estimate against measurement, compound 4: 22-fold (1.34 log units) above; measured number below the stated range.
By their numbers in this assay, from the lowest: compound 4; then compounds 1, 2 and 3 (each within the scatter of the next).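

In this assay, hydroxy in place of hydrogen on this aromatic carbon, which turns 1H-benzimidazol-2-yl into 4-hydroxy-1H-benzimidazol-2-yl, gives a 44-fold lower number from compound 1 to compound 4 (1.64 log units; beyond the scatter). The exchanges among trifluoromethoxy, methoxy and dimethylamino left the number unchanged at the digits printed, so this carbon of the core is the first place shown where a single change moves it beyond the scatter. Nothing available explains this step. From the compounds shown here alone, it remains open what an amine or a methoxy group on this same carbon would give. Going by these compounds, it is also open whether hydroxy here would give a similar step alongside the dimethylamino group of compound 3.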